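Nitrooxy-acylamino chalcones: paw edema notes

The source may hold more compounds than are shown below. What is called first, only, known or untested is meant among the compounds shown, and "the series" means these compounds.

Measured so far in a functional assay on the whole organism (strain albino) for inhibition, with Rattus norvegicus as the target, read by paw edema, with stated times of 30 min and 2 h, at a dose of 100 mg/kg by the oral route; on this read-out higher numbers stand for more inhibition at the one dose given (going by the name of the read-out) and lower numbers for less inhibition:
compound 1 `COc1ccc(/C=C/C(=O)c2ccc(NC(=O)CO[N+](=O)[O-])cc2)cc1` gives 49%.
compound 2 `O=C(CO[N+](=O)[O-])Nc1ccc(C(=O)/C=C/c2ccco2)cc1` gives 36%.
compound 3 `COc1ccc(/C=C/C(=O)c2ccc(NC(=O)C(C)O[N+](=O)[O-])cc2)cc1` gives 46%.

Two changes are covered by these three compounds. The first is furan-2-yl in place of 4-methoxyphenyl on a double-bonded chain carbon bound to a double-bonded chain carbon, which gave a number 13 percentage points lower from compound 1 to compound 2 (beyond the scatter). The second is methyl in place of hydrogen on a saturated chain carbon bound to a carbonyl carbon and an oxygen on an unsaturated carbon, which gave a number 3 percentage points lower from compound 1 to compound 3 (within the scatter), so the cores of compound 1 and compound 3 behave alike in this assay as far as these numbers can tell. Compound 3 stands within the scatter of compound 1, and its gap to compound 2 is also within the scatter, so no order among these three is claimed beyond the one step that is beyond the scatter.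

Compound 4 `CC(O[N+](=O)[O-])C(=O)Nc1ccc(C(=O)/C=C/c2ccco2)cc1` has not been measured. Among the measured compounds shown here, it differs from compound 3 by furan-2-yl in place of 4-methoxyphenyl on a double-bonded chain carbon bound to a double-bonded chain carbon, and this is the same change as the one made from compound 1 to compound 2, at the same place. For the measured compounds named here, since the two cores were separated only by a step within the scatter, the step from compound 3 to compound 4 is expected to be of about the size seen before, because a number 13 percentage points lower from compound 1 to compound 2 (beyond the scatter) is the only measure of this change available; the expected step is a number 13 percentage points lower from compound 3 to compound 4 (beyond the scatter). Compound 4 is therefore expected to give about 33% in this assay, estimated to lie between 20% and 46%.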

Compound 4, a percentage reported as inhibition, in the whole organism at one dose (the size of the read-out at that dose, not a potency): 48%
The estimate for compound 4 lay 15 percentage points below the measured number; measured number outside the range, above it.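

In this assay the new step reads a number 2 percentage points higher from compound 3 to compound 4 (within the scatter) and so furan-2-yl in place of 4-methoxyphenyl does not carry over as one fixed step from the core of compound 1 to the core of compound 3: the same change on two cores in this assay, a number 13 percentage points lower (beyond the scatter) from compound 1 to compound 2 and a number 2 percentage points higher (within the scatter) from compound 3 to compound 4, 15 percentage points apart, beyond the scatter of two such steps. Read along the other side of the same four compounds, methyl in place of hydrogen on a saturated chain carbon bound to a carbonyl carbon and an oxygen on an unsaturated carbon gives a number 12 percentage points higher from compound 2 to compound 4 (beyond the scatter) and this step also fails to match its earlier counterpart: the same change on two cores in this assay, a number 3 percentage points lower (within the scatter) from compound 1 to compound 3 and a number 12 percentage points higher (beyond the scatter) from compound 2 to compound 4, 15 percentage points apart, beyond the scatter of two such steps. In this one set of four compounds, the size of each step therefore depends on what stands at the other place, but the set does not show why, and it gives no rule for any further core.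

The compounds shown leave open whether this dependence persists with an ethyl group or a longer chain in place of methyl on the saturated chain carbon. They also leave open how thiophen-2-yl or plain phenyl in place of furan-2-yl would behave on either core.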